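A few compounds are considered here, and "the series" means these few. Any claim that something is new, unique, unknown or untested is made for them only; others in the source may bear on it.

Measured compounds:
Compound 1, `CCCCCCCCS(=O)(=O)Nc1ccc(-c2ccc(Cl)cc2)cc1C(=O)O`: 9200 nM
Compound 2, `CCCCCCCCS(=O)(=O)Nc1ccc(-c2ccccc2-c2ccccc2)cc1C(=O)O`: 10100 nM
Compound 3, `CCCCCCCCS(=O)(=O)Nc1ccc(-c2ccc(-c3ccccc3)cc2)cc1C(=O)O`: 29100 nM

In an assay on mitochondria (strain BALB/c) for inhibition of glycerol-3-phosphate acyltransferase 1, mitochondrial (Mus musculus), read by scintillation counting, with a stated time of 10 min (a lower number here means a stronger inhibitor, a higher number a weaker inhibitor), compound 3 gives the highest of the three numbers; compound 2 sits nearest to it, and compound 1 furthest, both beyond the usual scatter, so compound 3 is the weakest inhibitor of the set measured so far. Compound 4, `CCCCCCCCS(=O)(=O)Nc1ccc(-c2ccc(O)cc2)cc1C(=O)O`, is not yet measured. It differs from compound 3 in one place: hydroxy in place of phenyl on an aromatic carbon.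

Among the measured compounds shown here, only one measured step bears on this change, and only in reverse. Going from the chloro of compound 1 to the phenyl of compound 3 gave a 3.2-fold higher number from compound 1 to compound 3 (0.50 log units; beyond the scatter). Compound 4 removes that phenyl again and puts a single hydroxy in its place, a group far closer in size to the chloro of compound 1 than to the phenyl of compound 3. There is no direct measurement of a hydroxy at this position, so the direction is inferred from compound 1 alone.

Compound 4 is therefore expected to give a lower number than compound 3, a step of about a 2.4-fold lower number from compound 3 to compound 4 (0.38 log units; beyond the scatter) in this assay. The estimate for compound 4 is 12000 nM, with a range from 4000 nM to 35000 nM.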

Compound 4, half-maximal inhibitory concentration: 47300 nM
Compound 4: middle estimate off by 3.9-fold (0.60 log units), on the low side; the whole stated range lies below it.
By their numbers in this assay, from the lowest: compounds 1 and 2 (each within the scatter of the next); then compounds 3 and 4 (each within the scatter of the next).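

In this assay, hydroxy in place of phenyl gives a 1.6-fold higher number from compound 3 to compound 4 (0.21 log units; within the scatter), so this position tolerates an exchange from a six-membered aromatic ring to a single oxygen-bearing group without the two compounds being told apart. Hydroxy in place of chloro gives a 5.1-fold higher number from compound 1 to compound 4 (0.71 log units; beyond the scatter), which adds to a 3.2-fold higher number from compound 1 to compound 3 (0.50 log units; beyond the scatter) and shows that, among the three groups compared at this position, chloro alone stands apart, while a one-atom hydroxy and a six-atom phenyl do not separate, so the count of heavy atoms in the group does not order these numbers. No measurement on hand explains why chloro differs from the other two groups.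

The compounds shown leave open whether fluoro, bromo, methyl or methoxy at this place would group with chloro or with hydroxy and phenyl, and whether an amine or a carboxylic acid would fall with hydroxy. They also leave open whether the same grouping would hold with a shorter chain on the sulfonyl group.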